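Adding a chloro group to a urea-linked growth inhibitor

The source may hold more compounds than are shown below. What is called first, only, known or untested is meant among the compounds shown, and "the series" means these compounds.

Compound 1 `COc1cc(-c2nn(-c3cccc(NC(=O)c4cccc(C(F)(F)F)c4)c3)cc2-c2ccncc2)ccc1Cl` gives 1430 nM in a functional assay on MCF7 cells (Homo sapiens) for inhibition, read by sulforhodamine B assay, with a stated time of 48 h; on this read-out lower numbers stand for stronger inhibition of growth and higher numbers for weaker inhibition of growth. Compound 2 `COc1cc(-c2nn(-c3cccc(NC(=O)Nc4cccc(C(F)(F)F)c4)c3)cc2-c2ccncc2)ccc1Cl` gives 751 nM in this assay, the lowest of the two numbers, while a 1.9-fold lower number from compound 1 to compound 2 (0.28 log units; within the scatter). Compound 3 `COc1cc(-c2nn(-c3cccc(NC(=O)Nc4ccc(Cl)c(C(F)(F)F)c4)c3)cc2-c2ccncc2)ccc1Cl` differs from compound 2 by chloro in place of hydrogen on an aromatic carbon. Among the compounds with values here, no measured step describes such a change; the only step on record, from compound 1 to compound 2, concerns a different place. The step of a 1.3-fold lower number from compound 2 to compound 3 (0.10 log units; within the scatter) is therefore expected to stay within the scatter. Compound 3 is estimated to give 600 nM in this assay, with a range from 250 nM to 1500 nM.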

Compound 3, concentration for 50% growth inhibition: 919 nM
Estimate against measurement, compound 3: 1.5-fold (0.19 log units) below; low and high end bracket the measured number.
By their numbers in this assay, from the lowest: compounds 2, 3 and 1 (each within the scatter of the next).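

In this assay, chloro on the aromatic carbon ortho to the trifluoromethyl group and para to a large group gives a 1.2-fold higher number from compound 2 to compound 3 (0.09 log units; within the scatter) and stays within the scatter, so this position accepts the added atom without a readable change in growth inhibition. The wider difference on the carbonyl carbon gives a 1.6-fold lower number from compound 1 to compound 3 (0.19 log units; within the scatter) and is also within the scatter. No measurement shown here helps to explain this result. Still open, going by these compounds, is whether an amine or a carboxylic acid on this same carbon would move the number beyond the scatter.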